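This account rests on a few compounds, and the source may have more. Where it says the series, first, only, none or still open, it means among the compounds named here.

Among the compounds with values here, in a functional assay on MOLT-4 cells (Homo sapiens) for antiproliferative activity (a lower number here means a stronger inhibitor, a higher number a weaker inhibitor), three compounds sharing one core have numbers so far. Compound 1 `COc1cc(C(=O)c2sc(-c3ccccc3)cc2N)cc(OC)c1OC` gives 5.3 nM, compound 2 `COc1cc(C(=O)c2sc(-c3ccncc3)cc2N)cc(OC)c1OC` gives 88 nM, and compound 3 `COc1cc(C(=O)c2sc(-c3ccc(F)cc3)cc2N)cc(OC)c1OC` sits between them at 12 nM. Compound 4 `COc1ccc(-c2cc(N)c(C(=O)c3cc(OC)c(OC)c(OC)c3)s2)cc1` has methoxy in place of fluoro on an aromatic carbon, para to a large group (methoxy in place of fluoro on an aromatic carbon). Within the data shown here, the closest precedent is the modest 2.3-fold higher number from compound 1 to compound 3 (0.35 log units; beyond the scatter), where only one group on that carbon changes. The large 17-fold higher number from compound 1 to compound 2 (1.22 log units; beyond the scatter) and the modest 7.3-fold lower number from compound 2 to compound 3 (0.87 log units; beyond the scatter) involve a change of the ring itself, so they bear less on this swap. In this assay, no step beyond the scatter is therefore expected. The estimated step is a 1.3-fold lower number from compound 3 to compound 4 (0.12 log units; within the scatter). Compound 4 is expected near 9 nM, within an estimated range of 3 nM to 28 nM.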

Compound 4, half-maximal inhibitory concentration: 18 nM
The estimate for compound 4 lay 2.0-fold (0.30 log units) below the measured number; low and high end bracket the measured number.
By their numbers in this assay, from the lowest: compound 1; then compounds 3 and 4 (each within the scatter of the next); then compound 2.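

In this assay, methoxy and fluoro on this aromatic carbon cannot be told apart (a 1.5-fold higher number from compound 3 to compound 4 (0.18 log units; within the scatter)). Against the unsubstituted phenyl, however, methoxy gives a weaker inhibitor (a 3.4-fold higher number from compound 1 to compound 4 (0.53 log units; beyond the scatter)), so both groups tried at this place, fluoro in compound 3 and methoxy in compound 4, read weaker than hydrogen. A 4-methoxyphenyl group still clearly outperforms pyridin-4-yl (a 4.9-fold lower number from compound 2 to compound 4 (0.69 log units; beyond the scatter)).

Nothing measured here explains these differences. Going by these compounds, whether an amine, a carboxylic acid or a longer chain such as ethoxy on this carbon would fit the same picture remains open.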